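The source may hold more compounds than are shown below. What is called first, only, known or untested is meant among the compounds shown, and "the series" means these compounds.

Of the compounds shown here, three have so far been tested in an ADME assay on MDCK cells (Canis lupus familiaris) for cytotoxicity, read by MTT assay, with a stated time of 24 h; a higher number here means that more compound is tolerated, a lower number that less compound is tolerated. Compound 1 `Cc1cc(CNS(=O)(=O)c2ccc([N+](=O)[O-])cc2)c(C)o1` gives only a limit, > 152000 nM. Compound 2 `O=[N+]([O-])c1ccc(S(=O)(=O)NCc2csc3ccccc23)cc1` also gives only a limit, > 191000 nM. Compound 3 `O=S(=O)(NCc1csc2ccccc12)c1ccc(Cl)cc1` is the only one of the three with an actual number, 69600 nM, so it has no measured neighbour to be ranked against exactly.

Compound 4 `Cc1ccc(S(=O)(=O)NCc2csc3ccccc23)cc1` has yet to be measured. It differs from compound 3 by methyl in place of chloro on an aromatic carbon, para to a large group: methyl in place of chloro on an aromatic carbon.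

Within the data shown here, one measured step bears on this change, and it concerns the same aromatic carbon. That step is an at least 2.7-fold lower number from compound 2 to compound 3 (0.43 log units; beyond the scatter), with chloro in place of nitro, which shows that this assay can respond to a change at this carbon. Its size is only a lower bound, however, and it involves nitro, which compound 4 does not carry. Among the measured compounds shown here, the data contain no measured step between chloro and methyl, so the direction of the new change remains open.

The expected change is a 1.1-fold higher number from compound 3 to compound 4 (0.06 log units; within the scatter), which is not anticipated to lie beyond the scatter. The estimated value for compound 4 is 80000 nM, with an expected range of 35000 nM to 180000 nM.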

Compound 4, half-maximal cytotoxic concentration: > 210000 nM
Compound 4: only a limit was reported; the forecaster's own chance of this, stated with the estimate: 30%; middle value at least 2.6-fold (0.41 log units) from the limit.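

In this assay, among these compounds, methyl in place of chloro on this aromatic carbon moves the number beyond the scatter, an at least 3.0-fold higher number from compound 3 to compound 4 (0.47 log units; beyond the scatter), which gives the first measured step between these two groups. Read together with an at least 2.7-fold lower number from compound 2 to compound 3 (0.43 log units; beyond the scatter), it sets chloro apart from both nitro and methyl at this carbon: among the compounds sharing this core, only compound 3 gives an actual number, and both steps that can be read run towards it as the lower one, while the step between compound 2 and compound 4 cannot be read. The size of the new step is only a lower bound, as the result for compound 4 is a limit and not a number: the limit of > 210000 nM in this assay, at which 1 of the 4 values shown sits.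

The compounds shown leave open how far compound 4 really lies from compound 3, and whether a bromo or a methoxy group on this carbon would go with a lower number, as chloro does, or with a limit, as nitro and methyl do. They also leave open whether chloro would lower the number on the core of compound 1 as it does on the core of compound 3.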